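This account rests on a few compounds, and the source may have more. Where it says the series, first, only, none or still open, it means among the compounds named here.

Measured in a functional assay on MDA-MB-231 cells (Homo sapiens) for cytotoxicity, read by MTT assay, with a stated time of 24 h; on this read-out lower numbers stand for stronger inhibition and higher numbers for weaker inhibition:
- compound 1 `COC(=O)c1ccc(-c2nc3cccnc3n2C2CCCC2)cc1`: 350 nM
- compound 2 `O=C(NCc1ccccc1)c1ccc(-c2nc3cccnc3n2C2CCCC2)cc1`: 620 nM
- compound 3 `c1cnc2c(c1)nc(-c1cncnc1)n2C1CCCC1`: > 10000 nM

Compound 3 gives > 10000 nM, which is a limit of the assay and not a number. Of the two real numbers, compound 2 at 620 nM lies within the scatter of compound 1 at 350 nM.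

Next is compound 4 `c1cnc2c(c1)nc(-c1ccc(-c3nnco3)cc1)n2C1CCCC1`, with 1,3,4-oxadiazol-2-yl in place of benzylcarbamoyl on an aromatic carbon. Among the measured compounds shown here, the one measured step that bears on this place is a 1.8-fold higher number from compound 1 to compound 2 (0.25 log units; within the scatter). That step only exchanged the group on a carbonyl carbon, whereas here the whole benzylcarbamoyl leaves, so it is a weak guide. On that small step, no clear shift beyond the scatter is expected in this assay, though a higher number is the likelier direction. The expected step is a 1.5-fold higher number from compound 2 to compound 4 (0.16 log units; within the scatter). With compound 3 at the limit of > 10000 nM in this assay, at which 1 of the 3 values shown sits, the expected range stays wide on the upper side. For compound 4 the estimated value is 900 nM, with an expected range from 200 nM to 5000 nM.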

Compound 4, half-maximal inhibitory concentration: 87 nM
Compound 4: middle estimate off by 10-fold (1.01 log units), on the high side; the measured number lies below the stated range.
By their numbers in this assay, from the lowest: compound 4; then compounds 1 and 2 (each within the scatter of the next). At a limit, above all of these: compound 3.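

In this assay the group on this aromatic carbon, para to a large group, can move the number beyond the scatter, which the exchange on the carbonyl carbon alone did not do. With 1,3,4-oxadiazol-2-yl in place of benzylcarbamoyl the change is a 7.1-fold lower number from compound 2 to compound 4 (0.85 log units; beyond the scatter) and with it in place of methoxycarbonyl the change is a 4.0-fold lower number from compound 1 to compound 4 (0.60 log units; beyond the scatter) on the same aromatic carbon. Among these compounds, then, the lowest number comes with no carbonyl on this carbon and without the six-membered aromatic ring of the benzylcarbamoyl group.

Whether this reflects the 1,3,4-oxadiazol-2-yl ring in particular stays open, since a carboxylic acid, a nitrile or an amine at the same place is not among the compounds shown. The data shown offer no explanation for the lower number.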